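This account rests on a few compounds, and the source may have more. Where it says the series, first, only, none or still open, it means among the compounds named here.

In an assay on U2OS cells for activation of nuclear factor erythroid 2-related factor 2 (Homo sapiens), read by beta-arrestin recruitment, with a stated time of 6 h (a lower number here means that less compound is needed, a higher number that more compound is needed for the effect), compound 1 `O=S(=O)(/C=C\c1ncccc1Cl)c1cccc(F)c1` gives 2160 nM, compound 2 `O=S(=O)(/C=C/c1ncccc1F)c1cccc(Cl)c1` gives 198 nM and compound 3 `O=S(=O)(/C=C\c1ncccc1F)c1cccc(Cl)c1` gives 252 nM. Compound 3 thus holds the second highest of the three numbers: compound 2 lies within the scatter of it, while compound 1 stands apart with a higher number beyond the scatter. Among the compounds with values here, the only measured step, a 1.3-fold higher number from compound 2 to compound 3 (0.10 log units; within the scatter), stays within the scatter, in line with the fact that compounds 2 and 3 differ only in the configuration as drawn. Compound 4 `O=S(=O)(/C=C\c1ncccc1Cl)c1cccc(Cl)c1` arises from compound 3 through (chloro in place of fluoro on an aromatic carbon). Within the data shown here, no measured step isolates this exchange; the step from compound 2 to compound 3 concerns only the drawn configuration and says nothing about it. Compound 1 does carry chloro on its six-membered aromatic ring with one nitrogen, yet it differs from compound 3 in a second place as well, so its higher number cannot be assigned to the chloro alone. Compound 4 is therefore expected to show a step of a 2.0-fold higher number from compound 3 to compound 4 (0.30 log units; within the scatter), leaning toward a somewhat higher number with wide uncertainty. Compound 4 is estimated at 500 nM, within a range from 150 nM to 1800 nM.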

Compound 4, half-maximal effective concentration: 290 nM
The estimate for compound 4 lay 1.7-fold (0.24 log units) above the measured number; low and high end bracket the measured number.
By their numbers in this assay, from the lowest: compounds 2, 3 and 4 (each within the scatter of the next); then compound 1.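

In this assay, the place on an aromatic carbon of the six-membered aromatic ring with 1 nitrogen, ortho to a large group and two atoms from the ring nitrogen, tolerates chloro as well as fluoro: a 1.2-fold higher number from compound 3 to compound 4 (0.06 log units; within the scatter). The same exchange at the other fluoro or chloro place in the shared core is not neutral, and it now accounts for the gap between compound 1 and the rest, with a 7.4-fold lower number from compound 1 to compound 4 (0.87 log units; beyond the scatter). Nothing available gives a cause for either step.

From the compounds shown here alone, both groups at the first place are single halogen atoms, so it remains open whether an amine, a methoxy group or a longer chain would be tolerated there as well. At the other place, only fluoro and chloro are compared, which leaves a nitrile or a carboxylic acid an open question.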